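From 4-bromophenyl to 3-methoxyphenyl on the carbonyl

This account rests on a few compounds, and the source may have more. Where it says the series, first, only, none or still open, it means among the compounds named here.

In a functional assay on L1210 cells (Mus musculus) for antiproliferative activity, read by cell counting, with a stated time of 2 days (on this read-out higher numbers stand for weaker inhibition and lower numbers for stronger inhibition), compound 1 (`COc1ccc(Nc2nc(N)c(C(=O)c3ccc(Br)cc3)s2)cc1`) gives 110 nM and stands lowest of the three measured numbers. Compound 3 (`COc1ccc(Nc2nc(N)c(C(=O)c3ccc([N+](=O)[O-])cc3)s2)cc1`) gives 280 nM and compound 2 (`Cc1ccc(Nc2nc(-n3ccnc3C)cs2)cc1`) gives 1800 nM on the same read-out. Compound 4 (`COc1ccc(Nc2nc(N)c(C(=O)c3cccc(OC)c3)s2)cc1`) is still unmeasured and carries 3-methoxyphenyl in place of 4-bromophenyl on a carbonyl carbon. Nitro in place of bromo on an aromatic carbon gives a 2.5-fold higher number from compound 1 to compound 3 (0.41 log units; beyond the scatter) as the only measured step, a modest one beyond the scatter. Among the compounds with values here, no measured compound carries 3-methoxyphenyl, so that step is only a rough guide. A modest step of similar size towards a higher number is therefore expected (a 2.7-fold higher number from compound 1 to compound 4 (0.44 log units; beyond the scatter)). For compound 4 the estimate is 300 nM (100 nM to 900 nM).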

Compound 4, half-maximal inhibitory concentration: 35 nM
Beside the measured number, compound 4's estimate is 8.6-fold (0.93 log units) above it; the measured number lies below the stated range.
By their numbers in this assay, from the lowest: compound 4; then compound 1; then compound 3; then compound 2.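

Within the data shown here, the aryl group on the carbonyl proves able to move the number in either direction in this assay: the only earlier step, a 2.5-fold higher number from compound 1 to compound 3 (0.41 log units; beyond the scatter), went upward, whereas this change gives a 3.1-fold lower number from compound 1 to compound 4 (0.50 log units; beyond the scatter). Compound 1 therefore no longer marks the lowest number reached at this position. No evidence is available that accounts for this change. The compounds shown leave open whether the lower number comes from the methoxy group, from where it sits, or from the loss of bromine. As far as these compounds go, how an amine, a carboxylic acid or a longer chain such as ethoxy would read on this ring also remains open.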